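Series notes: compound 3 to compound 4

The source may report more compounds than this note shows. Statements on the series, on what has been measured and on what is new or still open speak of the compounds shown alone.

Three compounds with a shared core have numbers in a functional assay on PC-3 cells (Homo sapiens) for inhibition, read by MTT assay, with a stated time of 72 h; a lower number here means a stronger inhibitor, a higher number a weaker inhibitor. Compound 1 `CC(C)n1ncc2c(C(=O)NC3CCCC3)cccc21` gives 19400 nM in this assay. Compound 2 `CC(C)n1ncc2c(C(=O)NCc3ccccc3)cccc21` gives 15200 nM in this assay, and the step of a 1.3-fold lower number from compound 1 to compound 2 (0.11 log units; within the scatter) lies within the scatter. Among the measured compounds shown here, compound 3 `CC(C)n1ncc2c(C(=O)NCc3cn(-c4ccc([N+](=O)[O-])cc4)nn3)cccc21` reaches only the limit > 40000 nM in this assay, so no number is known for it; this is the limit of > 40000 nM in this assay, at which 1 of the 3 values shown sits, and compound 3 is the one value sitting there.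

Compound 4 `COc1ccc(Cn2cc(CNC(=O)c3cccc4c3cnn4C(C)C)nn2)cc1` differs from compound 3 by 4-methoxybenzyl in place of 4-nitrophenyl on an aromatic nitrogen, on an aromatic nitrogen of a five-membered aromatic ring with 3 nitrogen. For the measured compounds named here, the single measured step concerns the amide-type nitrogen, not this ring nitrogen, and was within the scatter; no measured step therefore bears on this change. With compound 3 known only as a limit, no step beyond the scatter is expected in this assay, and the result is expected to remain near the limit. Compound 4 is expected at 45000 nM, within 15000 nM to 120000 nM. The expected step is a step that the limit leaves unreadable from compound 3 to compound 4.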

Compound 4, half-maximal inhibitory concentration: 34000 nM
The estimate for compound 4 lay 1.3-fold (0.12 log units) above the measured number; low and high end bracket the measured number.
By their numbers in this assay, from the lowest: compounds 2, 1 and 4 (each within the scatter of the next, the first and the last beyond it). At a limit, above all of these: compound 3.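

At this ring nitrogen, the only position on the five-membered aromatic ring with 3 nitrogen that varies here, 4-methoxybenzyl in place of 4-nitrophenyl gives an at least 1.1-fold lower number from compound 3 to compound 4 (0.07 log units; that floor lies within the scatter). In this assay, compound 4 gives 34000 nM, the first number readable for a compound carrying this ring. Compound 3 is a limit, and the true size of the step stays unknown because of that limit: the limit of > 40000 nM in this assay, at which 1 of the 4 values shown sits.

The single change replaces both the nitro group and the direct ring attachment, so the compounds shown do not separate these two parts. Also open, on these data alone, is how this ring nitrogen responds to a plain benzyl, a longer alkyl chain, or a benzyl bearing an amine or a carboxylic acid.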